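Reducing the ketone in a four-membered lactam series

This account rests on a few compounds, and the source may have more. Where it says the series, first, only, none or still open, it means among the compounds named here.

Measured compounds:
- compound 1 `COc1ccc([C@@H]2[C@@H](C(=O)c3ccsc3)C(=O)N2c2cc(OC)c(OC)c(OC)c2)cc1`: 470 nM
- compound 2 `COc1ccc([C@@H]2[C@@H](c3cccs3)C(=O)N2c2cc(OC)c(OC)c(OC)c2)cc1O`: 7 nM
- compound 3 `COc1ccc([C@@H]2[C@@H](c3cccs3)C(=O)N2c2cc(OC)c(OC)c(OC)c2)cc1N`: 42 nM

All three were tested in a functional assay on MCF7 cells (Homo sapiens) for antiproliferative activity, read by MTT assay; on this read-out higher numbers stand for weaker inhibition and lower numbers for stronger inhibition. Compound 1 gives the highest number of the three; compound 3 sits nearest to it and compound 2 furthest from it, both gaps beyond the scatter. Within the data shown here, compounds 2 and 3 differ from compound 1 in more than one place, so their values show only that the shared core can reach far stronger inhibition.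

The unmeasured compound 4 `COc1ccc([C@@H]2[C@@H](C(O)c3cccs3)C(=O)N2c2cc(OC)c(OC)c(OC)c2)cc1` differs from compound 1 in a single place: hydroxy(thiophen-2-yl)methyl in place of (thiophen-3-yl)carbonyl on a saturated ring carbon. Among the measured compounds shown here, the only measured step, a 6.0-fold higher number from compound 2 to compound 3 (0.78 log units; beyond the scatter), concerns an amino in place of hydroxy on an aromatic carbon, a different site and a different kind of change, so it does not bear on this step. For the measured compounds named here, no measured pair shows what a hydroxy(thiophen-2-yl)methyl group does in place of a (thiophen-3-yl)carbonyl group.

Going by the values given here, with no direct precedent, compound 4 is expected to move only modestly, with wide uncertainty: an estimated step of a 1.9-fold lower number from compound 1 to compound 4 (0.27 log units; within the scatter). Compound 4 is therefore estimated at 250 nM, within a range from 40 nM to 1500 nM.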

Compound 4, half-maximal inhibitory concentration: 1200 nM
Compound 4: middle estimate off by 4.8-fold (0.68 log units), on the low side, and the stated range covers the measured number.
By their numbers in this assay, from the lowest: compound 2; then compound 3; then compound 1; then compound 4.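

In this assay, replacing the group on this saturated ring carbon gives a 2.6-fold higher number from compound 1 to compound 4 (0.41 log units; beyond the scatter), so the position responds to what it carries, even though both groups hold 7 heavy atoms and one five-membered aromatic ring. This single step bundles two edits: the carbonyl gives way to a carbon bearing a hydroxy group, bringing 1 hydrogen-bond donor where the leaving group has 0, and the thiophen-3-yl becomes a thiophen-2-yl, so the weaker inhibition cannot be credited to either edit alone. No measurement on hand accounts for the shift, so its cause remains unknown.

The compounds shown leave open which edit carries the step; a (thiophen-2-yl)carbonyl group or a hydroxy(thiophen-3-yl)methyl group on the same carbon would pull the two apart. Also open, going by these compounds, is whether the hydroxy itself matters on this carbon, which an amino(thiophen-2-yl)methyl group, with an amine in its place, could begin to test.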